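The source may hold more compounds than are shown below. What is called first, only, known or untested is meant among the compounds shown, and "the series" means these compounds.

Measured compounds:
compound 1, `COc1ccc(C2=NN(C3=NC(=O)/C(=C4\C(=O)Nc5ccccc54)S3)C(c3ccc(OC)cc3)C2)cc1`, 81500 nM
compound 2, `COc1ccc(C2=NN(C3=NC(=O)/C(=C4\C(=O)Nc5ccc(Br)cc54)S3)C(c3ccc(OC)cc3)C2)cc1`, 210 nM
compound 3, `CN(C)c1ccc(C2CC(c3ccccc3)=NN2C2=NC(=O)/C(=C3\C(=O)Nc4ccccc43)S2)cc1`, 5260 nM

All three were run in a functional assay on cells (Cancer cell lines, Homo sapiens) for cytotoxicity, read by sulforhodamine B assay, with a stated time of 48 h; a lower number here means a stronger inhibitor of growth, a higher number a weaker inhibitor of growth. Compound 1 and compound 2 share one core and differ by a single change, (bromo in place of hydrogen on an aromatic carbon), which gave a 390-fold lower number from compound 1 to compound 2 (2.59 log units; beyond the scatter). Compound 3 is built on a second core; the difference between the two cores is not broken down here. In this assay compound 3 gives 5260 nM, a lower number than compound 1 and a higher number than compound 2.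

Compound 4, `CN(C)c1ccc(C2CC(c3ccccc3)=NN2C2=NC(=O)/C(=C3\C(=O)Nc4ccc(Br)cc43)S2)cc1`, is not yet measured. It stands to compound 3 as compound 2 stands to compound 1: the change is bromo in place of hydrogen on an aromatic carbon, the same change, at the same place, as seen once before in this series. Within the data shown here, for compound 4 a step of a 110-fold lower number from compound 3 to compound 4 (2.02 log units; beyond the scatter) is expected, smaller than the single earlier step of a 390-fold lower number from compound 1 to compound 2 (2.59 log units; beyond the scatter). That earlier step has been seen only once, and on a different core. Compound 4 is estimated at 50 nM in this assay, with a range of 8 nM to 400 nM.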

Compound 4, concentration for 50% growth inhibition: 220 nM
Compound 4: the middle estimate sits 4.4-fold (0.64 log units) below what was measured, within the range that was stated.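

In this assay, bromo in place of hydrogen on an aromatic carbon again gives a lower number, a 24-fold lower number from compound 3 to compound 4 (1.38 log units; beyond the scatter), so the direction of the change holds on both the core of compound 1 and the core of compound 3. Among these compounds, the size of the step does not carry over unchanged from one core to the other: the same change on two cores in this assay, a 390-fold lower number (2.59 log units; beyond the scatter) from compound 1 to compound 2 and a 24-fold lower number (1.38 log units; beyond the scatter) from compound 3 to compound 4, 16-fold (1.21 log units) apart, beyond the scatter of two such steps With only one pair on each core, and with the two cores differing in more than one place, these data do not show which structural difference goes with the difference in step size, nor how the change would behave on a further core.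

Open, on these data alone, is whether chloro, fluoro or a nitrile at the same place would give a step like that of bromo on either core. Among the compounds shown here, also open is whether the size of the step follows the methoxy groups or the dimethylamino group, a question that a core carrying only one of these groups could address.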